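Urea aryl group swap in a pyrazole series on melanoma cells

The source may report more compounds than this note shows. Statements on the series, on what has been measured and on what is new or still open speak of the compounds shown alone.

Measured compounds:
compound 1, `COc1cc(Cl)cc(-c2nn(-c3cccc(NC(=O)Nc4ccc(Cl)c(C(F)(F)F)c4)c3)cc2-c2ccncc2)c1`, 95%
compound 2, `COc1cc(Cl)cc(-c2nn(-c3cccc(NC(=O)Nc4cc(C(F)(F)F)cc(C(F)(F)F)c4)c3)cc2-c2ccncc2)c1`, 96%
compound 3, `COc1cc(Cl)cc(-c2nn(-c3cccc(NC(=O)Nc4ccc(Cl)c(Cl)c4)c3)cc2-c2ccncc2)c1`, 95%

In a functional assay on UACC-62 cells (Homo sapiens) for inhibition, read by sulforhodamine B assay, with a stated time of 48 h, tested at 0.01 uM (a higher number here means a weaker effect of the compound at the concentration tested, a lower number a stronger effect), compound 3 gives 95%, and on that number it stands level with compound 1, the two together being the lowest of the three numbers shown. Compound 2 gives 96%, which lies within the scatter of the other two, so at this concentration the three measured compounds cannot be told apart.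

Compound 4, `COc1cc(Cl)cc(-c2nn(-c3cccc(NC(=O)Nc4cccc(C(F)(F)F)c4)c3)cc2-c2ccncc2)c1`, has not yet been measured in this assay. It differs from compound 3 in one place: 3-(trifluoromethyl)phenyl in place of 3,4-dichlorophenyl on an amide-type nitrogen. For the measured compounds named here, one measured step touches this kind of change: no change at the digits printed from compound 1 to compound 3 (within the scatter). That step, chloro in place of trifluoromethyl on an aromatic carbon, left the number unchanged within the scatter. The change to compound 4 is of a similar kind, an exchange among halogen-bearing aryl groups on the urea, and the three measured compounds, which all carry such groups, sit close together. Going by the values given here, no measured step points in either direction, and none goes beyond the scatter.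

Compound 4 is therefore expected to show a step of a number 1 percentage points higher from compound 3 to compound 4 (within the scatter), that is, no change beyond the scatter. The value of compound 4 in this assay is estimated at 96%, within a range from 88% to 101%.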

Compound 4, a percentage reported as activity, at one concentration (the size of the read-out at that concentration, not a potency): 96%
The estimate for compound 4 equals the measured number at the digits printed; the measured number falls inside the stated range.
By their numbers in this assay, from the lowest: compounds 1, 3, 2 and 4 (each within the scatter of the next).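

For the compounds shown here, compound 4 is the first compound here with a single substituent on the aryl ring of the urea, and in this assay losing the second substituent does not separate it from its two-substituent partners: the read-out shows no change at the digits printed from compound 2 to compound 4 (within the scatter) when hydrogen replaces trifluoromethyl on an aromatic carbon, and a number 1 percentage points higher from compound 1 to compound 4 (within the scatter) when hydrogen replaces chloro on an aromatic carbon. The exchange of 3,4-dichlorophenyl for 3-(trifluoromethyl)phenyl on the amide-type nitrogen, which gives a number 1 percentage points higher from compound 3 to compound 4 (within the scatter), is likewise within the scatter, so at this concentration the read-out does not distinguish among these four aryl groups. Nothing available explains this lack of separation.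

From the compounds shown here alone, all of these aryl groups carry chloro or trifluoromethyl, so it remains open whether an unsubstituted phenyl, or a ring bearing an amine or a carboxylic acid, would behave the same way on this nitrogen. Going by these compounds, it also remains open whether a longer alkyl chain in place of the aryl group would shift the number beyond the scatter in this assay.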